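The source may hold more compounds than are shown below. What is called first, only, known or untested is meant among the compounds shown, and "the series" means these compounds.

Among the compounds with values here, compound 1 `CCCSc1nc(N/N=C(\C)c2ccccc2O)c2nnn(Cc3ccc(O)cc3)c2n1` is the weaker of the two compounds measured so far. In a functional assay on ECa-109 cells (Homo sapiens) for antiproliferative activity, read by MTT assay, with a stated time of 72 h (on this read-out higher numbers stand for weaker inhibition and lower numbers for stronger inhibition), compound 1 gives 15900 nM, the highest number of the pair. Within the data shown here, its only neighbour, compound 2 `C#CCSc1nc(N/N=C/c2cc(OC)c(OC)c(OC)c2)c2nnn(Cc3ccccc3)c2n1`, gives 6540 nM in this assay, a lower number that lies beyond the usual scatter; the two compounds differ in several places at once, so the numbers say only that compound 2 is the stronger inhibitor.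

The step under consideration leads to compound 3 `CCCSc1nc(N/N=C(\C)c2ccccc2O)c2nnn(Cc3cccc(Cl)c3)c2n1`, which keeps the core of compound 1 and changes one group: 3-chlorophenyl in place of 4-hydroxyphenyl on a saturated chain carbon bound to an aromatic nitrogen. Among the measured compounds shown here, no measured pair isolates this change, so the size of the step in this assay can only be estimated. A small step toward a lower number is expected for compound 3, most likely not clearly beyond the scatter, so that the estimated step of a 1.6-fold lower number from compound 1 to compound 3 (0.20 log units; within the scatter) remains modest. Compound 3 is therefore expected to give about 10000 nM in this assay, within a range of 3500 nM to 30000 nM.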

Compound 3, half-maximal inhibitory concentration: 13000 nM
Compound 3: middle estimate off by 1.3-fold (0.11 log units), on the low side; low and high end bracket the measured number.
By their numbers in this assay, from the lowest: compounds 2, 3 and 1 (each within the scatter of the next, the first and the last beyond it).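

In this assay, within the data shown here, 3-chlorophenyl in place of 4-hydroxyphenyl on a saturated chain carbon bound to an aromatic nitrogen gives a 1.2-fold lower number from compound 1 to compound 3 (0.09 log units; within the scatter), the first step here that isolates a single place on the shared core. The hydrogen-bond donor and acceptor of 4-hydroxyphenyl are absent from 3-chlorophenyl, yet the two compounds stand within the scatter of each other, so this pair shows no dependence of the read-out on that hydroxy group. No further measurement bears on this result.

This step exchanges the group on the ring and its place together, so the compounds shown cannot separate the two. Also open, going by these compounds, is what 4-chlorophenyl, an unsubstituted phenyl, or an amine or carboxylic acid on that ring would give on this core.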